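This account rests on a few compounds, and the source may have more. Where it says the series, first, only, none or still open, it means among the compounds named here.

Measured compounds:
Compound 1 `Cn1cnnc1SCC(=O)Nc1ccc(-c2nc(-c3ccccc3)c(-c3ccccc3)n2C)cc1` — 86.1%
Compound 2 `Cc1nnc(SCC(=O)Nc2ccc(-c3nc(-c4ccccc4)c(-c4ccccc4)n3C)cc2)s1` — 87.1%
Compound 3 `CN1CCN(CC(=O)Nc2ccc(-c3nc(-c4ccccc4)c(-c4ccccc4)n3C)cc2)CC1` — 49.1%

In a functional assay on HT-29 cells (Homo sapiens) for cytotoxicity, read by MTT assay, with a stated time of 24 h, tested at 32 ug/mL (on this read-out lower numbers stand for a weaker effect and higher numbers for a stronger effect at the one concentration tested), compound 1 stands second highest of the three numbers, with compound 2 within the scatter of it a number 1 percentage points higher from compound 1 to compound 2 (within the scatter) and compound 3 far below it a number 37 percentage points lower from compound 1 to compound 3 (beyond the scatter). Compound 4 `CN(C)/C=C/N1CCN(CC(=O)Nc2ccc(-c3nc(-c4ccccc4)c(-c4ccccc4)n3C)cc2)CC1` has not been measured; it differs from compound 1 in one place (4-(2-(dimethylamino)ethenyl)piperazin-1-yl in place of (4-methyl-4H-1,2,4-triazol-3-yl)sulfanyl on a saturated chain carbon bound to a carbonyl carbon). For the measured compounds named here, the steps that bear on this change both trade the sulfanyl-linked ring for a piperazinyl group on the same carbon and were large: a number 37 percentage points lower from compound 1 to compound 3 (beyond the scatter) and a number 38 percentage points lower from compound 2 to compound 3 (beyond the scatter). A drop of similar size, beyond the scatter, is therefore expected, a number 34.1 percentage points lower from compound 1 to compound 4 (beyond the scatter). For compound 4 the estimated read-out in this assay is 52%, within the range 30% to 74%.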

Compound 4, a percentage reported as activity, at one concentration (the size of the read-out at that concentration, not a potency): 29.8%
Estimate against measurement, compound 4: 22.2 percentage points above; measured number outside the range, below it.
By their numbers in this assay, from the lowest: compound 4; then compound 3; then compounds 1 and 2 (each within the scatter of the next).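

In this assay, the group carried on the ring nitrogen of the piperazinyl unit also matters: 2-(dimethylamino)ethenyl in place of methyl gives a number 19.3 percentage points lower from compound 3 to compound 4 (beyond the scatter). The loss on leaving the sulfanyl-linked rings therefore deepens, with a number 56.3 percentage points lower from compound 1 to compound 4 (beyond the scatter) and a number 57.3 percentage points lower from compound 2 to compound 4 (beyond the scatter). Nothing available explains these drops.

Going by these compounds, it remains open whether a saturated 2-(dimethylamino)ethyl group on that nitrogen would behave like the ethenyl group or like methyl. A free ring amine hydrogen or a longer alkyl chain at that place is equally untested here.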